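A few compounds are considered here, and "the series" means these few. Any claim that something is new, unique, unknown or untested is made for them only; others in the source may bear on it.

Measured compounds:
compound 1 `CC(C)(NC(=O)c1nc(-c2nccs2)sc1C1CC1)c1ccc(C(=O)NO)cc1` — 148 nM
compound 2 `C[C@H](NC(=O)c1nc(-c2ncc(-c3ccc(F)cc3)s2)sc1C1CC1)c1ccc(C(=O)NO)cc1` — 2.02 nM
compound 3 `COc1ccc(-c2cnc(-c3nc(C(=O)N[C@@H](C)c4ccc(C(=O)NO)cc4)c(C4CC4)s3)s2)cc1` — 2.38 nM

In an assay on cells for inhibition of protein deacetylase HDAC6 (Homo sapiens), read by fluorescence, with a stated time of 24 h (a higher number here means a weaker inhibitor, a lower number a stronger inhibitor), compound 1 gives 148 nM, the highest of the three numbers; compound 3 gives 2.38 nM and compound 2 gives 2.02 nM, both far below it and beyond the scatter. Going by the values given here, the only single-change step among the measured compounds, a 1.2-fold higher number from compound 2 to compound 3 (0.07 log units; within the scatter), lies within the scatter and concerns a different part of the molecule.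

Compound 4 `CC(NC(=O)c1nc(-c2nccs2)sc1C1CC1)c1ccc(C(=O)NO)cc1` differs from compound 1 by hydrogen in place of methyl on a saturated chain carbon bound to an amide-type nitrogen, an aromatic carbon and a saturated chain carbon. Among the compounds with values here, no measured pair tests this change on its own. Compounds 2 and 3 carry the same hydrogen in place of methyl at that carbon, but each also carries an added aryl group on the core that compound 1 and compound 4 lack, so their gap to compound 1 cannot be split between the two changes. The step in this assay is therefore uncertain in size; the direction taken from compounds 2 and 3 is downward, but only part of their gap is credited to the methyl removal.

Compound 4 is expected at 35 nM, within 8 nM to 150 nM, an estimated step of a 4.2-fold lower number from compound 1 to compound 4 (0.63 log units; beyond the scatter).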

Compound 4, half-maximal inhibitory concentration: 41.7 nM
Beside the measured number, compound 4's estimate is 1.2-fold (0.08 log units) below it; the range from low to high includes it.
By their numbers in this assay, from the lowest: compounds 2 and 3 (each within the scatter of the next); then compound 4; then compound 1.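

In this assay, hydrogen in place of methyl on a saturated chain carbon bound to an amide-type nitrogen, an aromatic carbon and a saturated chain carbon gives a 3.5-fold lower number from compound 1 to compound 4 (0.55 log units; beyond the scatter), a modest step but one beyond the scatter. Going by these compounds alone, this is the first reading of this position with only that change in play, and it shows that the number responds to substitution at this carbon on the shared core without an added aryl group. Compound 4 keeps one methyl at this carbon, so the result speaks to the loss of one methyl only, and nothing at hand offers a reason for the step.

From the compounds shown here alone, whether the step keeps its direction and size in the aryl-bearing compounds remains open, as does how each of the two mirror-image forms of compound 4 would read, since its structure is drawn without a defined configuration at this carbon. Also unsettled is how the number would respond to a second hydrogen at this carbon in place of the remaining methyl, or to an ethyl or hydroxymethyl group there.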